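This account rests on a few compounds, and the source may have more. Where it says the series, first, only, none or still open, it means among the compounds named here.

Three compounds built on one shared core have been examined in an ADME assay on L02 cells (Homo sapiens) for cytotoxicity, read by MTT assay, with a stated time of 24 h; a higher number here means that more compound is tolerated, a lower number that less compound is tolerated. Compound 1 `O=c1[nH]cc(S(=O)(=O)Nc2ccccc2-c2cn(-c3ccccc3F)nn2)c(=O)[nH]1`, compound 2 `O=c1[nH]cc(S(=O)(=O)Nc2ccccc2-c2cn(-c3cccc(F)c3)nn2)c(=O)[nH]1` and compound 3 `O=c1[nH]cc(S(=O)(=O)Nc2cccc(-c3cn(-c4ccccc4)nn3)c2)c(=O)[nH]1` differ only in where their outer groups sit and in whether a fluorine is present. For compound 1 this assay records > 100000 nM, which is a limit of the assay rather than a measured number. Compound 2 is simply reported as "not toxic" (no number reported), with no number at all. For compound 3 this assay gives > 100000 nM, again a limit and not a number. Compound 3 thus stands where compound 1 stands, and no ordering among the three can be read from these results; what the numbers show is only (the limit of > 100000 nM in this assay, at which 2 of the 3 values shown sit).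

Compound 4 `Cc1ccccc1-n1cc(-c2cccc(NS(=O)(=O)c3c[nH]c(=O)[nH]c3=O)c2)nn1` has not yet been measured. It differs from compound 3 by methyl in place of hydrogen on an aromatic carbon. Going by the values given here, no step between two measured compounds exists to set this change against, and the measured values all sit at the limit, so the change expected in this assay is none beyond the usual scatter. Compound 4 is therefore expected to give 100000 nM, within a range from 40000 nM to 250000 nM. The expected step is a number no higher from compound 3 to compound 4 (the limit leaves the size open).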

Compound 4, half-maximal cytotoxic concentration: 15300 nM
For compound 4 the middle estimate is 6.5-fold (0.82 log units) above the measured one; the whole stated range lies above it.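

A single added methyl, ortho to a large group on a six-membered aromatic ring of carbon only, is enough to change the outcome in this assay: going from phenyl to 2-methylphenyl gives an at least 6.5-fold lower number from compound 3 to compound 4 (0.81 log units; beyond the scatter). This means that less of the compound is tolerated by these cells, so this position on the outer ring is not indifferent to what is placed on it, even when the change is as small as one carbon. The earlier results could not reveal this, since they gave no number against which a change could be sized, and compound 4 is the first here to give a real number rather than a limit or a bare remark, which sets it apart from this ceiling: the limit of > 100000 nM in this assay, at which 2 of the 4 values shown sit.

Going by these compounds, what stays open is whether the drop belongs to methyl in particular or would also follow from another group at the same place, such as a methoxy group, a chlorine atom, an amine or a longer chain like ethyl. The compounds shown also leave open how far the number would fall with such groups, and why this single change has the effect it does.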